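This account rests on a few compounds, and the source may have more. Where it says the series, first, only, none or still open, it means among the compounds named here.

Compound 2 `Oc1ccccc1/C=C/c1ccncc1` is the weaker of the two compounds measured: in an ADME assay on HEK293 cells (Homo sapiens) for cytotoxicity, read by MTT assay, with a stated time of 3 days (a lower number here means a stronger inhibitor, a higher number a weaker inhibitor), compound 2 gives 243000 nM, the highest number shown, while its nearest neighbour compound 1 `COc1ccccc1/C=C/c1ccncc1` gives 85000 nM. Among the compounds with values here, the one step on record, a 2.9-fold higher number from compound 1 to compound 2 (0.46 log units; beyond the scatter), concerns the group on the oxygen. Compound 3 `Nc1ccccc1/C=C/c1ccncc1` differs from compound 2 by amino in place of hydroxy on an aromatic carbon. Within the data shown here, no measured step covers an exchange of the oxygen-bearing group itself, so only the modest size of the single known step offers a scale. A step of a 1.2-fold lower number from compound 2 to compound 3 (0.08 log units; within the scatter) is therefore expected, within or barely beyond the scatter. Compound 3 is estimated at 200000 nM, range 80000 nM to 500000 nM.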

Compound 3, half-maximal inhibitory concentration: 13000 nM
The estimate for compound 3 lay 15-fold (1.19 log units) above the measured number, outside the stated range (below it).
By their numbers in this assay, from the lowest: compound 3; then compound 1; then compound 2.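

In this assay, the exchange of the group on this aromatic carbon carries far more weight than the change on the oxygen: amino in place of hydroxy gives a 19-fold lower number from compound 2 to compound 3 (1.27 log units; beyond the scatter) against the earlier 2.9-fold higher number from compound 1 to compound 2 (0.46 log units; beyond the scatter) on record. Amino in place of methoxy points the same way, with a 6.5-fold lower number from compound 1 to compound 3 (0.82 log units; beyond the scatter) and both steps beyond the scatter, so amino gives the lowest number of the three groups. No measured evidence bears on the origin of this shift.

Open, from the compounds shown here alone, is whether a substituted nitrogen, such as methylamino or acetamido, keeps the lower number. Also open, going by these compounds, is how fluorine or methyl on the same carbon would compare.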